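Piperidinyl in Place of Chloro: An Expected Gain

A few compounds are considered here, and "the series" means these few. Any claim that something is new, unique, unknown or untested is made for them only; others in the source may bear on it.

Measured so far:
compound 1, `N#C/C(=C\c1ccc(Cl)cc1)C(=O)O`, 500 nM
compound 2, `CCCN(CCC)c1ccc(/C=C(\C#N)C(=O)O)cc1`, 10 nM

In an assay on RBE4 cells for inhibition of Monocarboxylate transporter 1 (Rattus norvegicus), with a stated time of 15 min (on this read-out lower numbers stand for stronger inhibition and higher numbers for weaker inhibition), compound 1 gives 500 nM, the highest of the two numbers recorded. Its nearest neighbour is compound 2, which in this assay gives 10 nM, a much lower number, and the gap between the two lies well beyond the scatter of the measurement.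

Compound 3, `N#C/C(=C\c1ccc(N2CCCCC2)cc1)C(=O)O`, has not yet been measured. It differs from compound 1 in one place: piperidin-1-yl in place of chloro on an aromatic carbon. Compound 2 carries a dipropylamino group in the same region and gives 10 nM, so compound 3, with a ring-closed amine in place of the chloro, is expected to behave more like compound 2 than like compound 1. The step from compound 1 to compound 3 is expected to be a large decrease, a 25-fold lower number from compound 1 to compound 3 (1.40 log units; beyond the scatter), well beyond the scatter. For compound 3 the estimate is 20 nM, within a range from 5 nM to 80 nM.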

Compound 3, half-maximal inhibitory concentration: 140 nM
Compound 3: the middle estimate sits 7.0-fold (0.85 log units) below what was measured; the measured number lies above the stated range.
By their numbers in this assay, from the lowest: compound 2; then compound 3; then compound 1.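

At this aromatic carbon, para to a group of 7 heavy atoms, piperidin-1-yl in place of chloro gives a 3.6-fold lower number from compound 1 to compound 3 (0.55 log units; beyond the scatter) in this assay, a modest step that still lies beyond the scatter. An amine on this carbon therefore does not by itself reach the level of the open-chain dipropylamino group: compound 2 gives 10 nM, while compound 3 gives 140 nM and stands between compound 2 and compound 1. No measurement shown explains why the ring-closed amine stops there.

As far as these compounds go, it remains open whether pyrrolidin-1-yl, morpholin-4-yl or an open-chain diethylamino group on this carbon would fall nearer compound 2 or compound 3. The compounds shown also leave open how a methyl ester in place of the carboxylic acid would read in this assay.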